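Chloro to hydrogen on the phenyl of compound 2

A few compounds are considered here, and "the series" means these few. Any claim that something is new, unique, unknown or untested is made for them only; others in the source may bear on it.

Two compounds carry numbers in a functional assay on RXF 393 cells (Homo sapiens) for antiproliferative activity, read by sulforhodamine B assay, with a stated time of 48 h; on this read-out higher numbers stand for weaker inhibition of growth and lower numbers for stronger inhibition of growth. Compound 1 `COc1ccc(OC)c(/C=C/c2nnc(Nc3ccc(Cl)cc3)o2)c1` gives 7920 nM in this assay. Compound 2 `COc1ccc(OC)c(/C=C/C(=O)N/N=C/c2ccc(Cl)cc2)c1` gives 298 nM in this assay, the lowest of the two values; compound 1 stands a long way from it, beyond the scatter. Going by the values given here, the two differ in many places at once, so what their values show is only that compound 2 is the stronger of the two, not which part of the difference matters.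

Compound 3 `COc1ccc(OC)c(/C=C/C(=O)N/N=C/c2ccccc2)c1` has not yet been measured in this assay. The change from compound 2 is hydrogen in place of chloro on an aromatic carbon of the six-membered aromatic ring of carbon only. Among the compounds with values here, no measured pair shows this step, so its size is a matter of expectation. Removing one heavy atom at the end of the molecule and leaving the rest untouched is expected to cost a little potency, a step from compound 2 to compound 3 of a 2.2-fold higher number from compound 2 to compound 3 (0.34 log units; beyond the scatter), though a move within the scatter cannot be ruled out. Compound 3 is therefore estimated at 650 nM in this assay, within a range from 250 nM to 1800 nM.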

Compound 3, concentration for total growth inhibition: 26600 nM
Compound 3: middle estimate off by 41-fold (1.61 log units), on the low side, and the stated range ends below it.
By their numbers in this assay, from the lowest: compound 2; then compound 1; then compound 3.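

In this assay, going by these compounds alone, replacing chloro with hydrogen on an aromatic carbon para to a large group gives an 89-fold higher number from compound 2 to compound 3 (1.95 log units; beyond the scatter), the first step that can be tied to a single place. The earlier comparison differed in many places at once and could not point to any one part, whereas this pair shows that the inhibition of growth by compound 2 depends strongly on what sits at this position, and that 4-chlorophenyl and phenyl are far from interchangeable on this core. The data at hand give no reason for the size of this step.

Still open, going by these compounds, is whether chloro itself matters here or whether another group at this position, such as fluoro, bromo, methyl, methoxy, an amine or a carboxylic acid, would keep the number of compound 2. Also open, on these data alone, is whether the same change from 4-chlorophenyl to phenyl on the core of compound 1 would move its number by anything like as much, or whether the large step belongs to the core shared by compound 2 and compound 3.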